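The source may hold more compounds than are shown below. What is called first, only, known or untested is meant among the compounds shown, and "the series" means these compounds.

Measured so far in a functional assay on PC-3 cells (Homo sapiens) for inhibition; on this read-out lower numbers stand for stronger inhibition and higher numbers for weaker inhibition:
compound 1 `Cc1c(C(=O)N/N=C\c2ccccc2C(F)(F)F)oc2cccc(O)c12` gives 26200 nM
compound 2 `Cc1c(C(=O)N/N=C\c2ccccc2O)oc2cccc(O)c12` gives 8350 nM
compound 3 `Cc1c(C(=O)N/N=C\c2ccc(O)cc2)oc2cccc(O)c12` gives 21700 nM

Among these three numbers compound 3 stands second highest. Going by the values given here, compound 1 lies within the scatter of compound 3, whereas the step of a 2.6-fold higher number from compound 2 to compound 3 (0.41 log units; beyond the scatter) lies beyond it, so compound 2 is the one measured compound that clearly separates from compound 3. Compound 4 `Cc1c(C(=O)N/N=C\c2cccc(F)c2O)oc2cccc(O)c12` differs from compound 3 in one place: 3-fluoro-2-hydroxyphenyl in place of 4-hydroxyphenyl on a carbon with a double bond to nitrogen. Among the compounds with values here, two measured steps bear on this. The step of a 2.6-fold higher number from compound 2 to compound 3 (0.41 log units; beyond the scatter) is the closest guide, since compound 4 carries its hydroxy on the ring carbon used by compound 2, and compound 4 is therefore expected to move back toward compound 2. Within the data shown here, the step of a 3.1-fold lower number from compound 1 to compound 2 (0.50 log units; beyond the scatter) concerns a trifluoromethyl and not a single fluorine, and no measured pair isolates a fluorine entering alongside the hydroxy, so the fluorine is treated as neutral. On that basis compound 4 is expected to give a modestly lower number, a 2.4-fold lower number from compound 3 to compound 4 (0.38 log units; beyond the scatter), in this assay. The estimate for compound 4 is 9000 nM, within 3500 nM to 23000 nM.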

Compound 4, half-maximal inhibitory concentration: 12700 nM
Compound 4: the middle estimate sits 1.4-fold (0.15 log units) below what was measured; measured number inside the range.
By their numbers in this assay, from the lowest: compounds 2, 4, 3 and 1 (each within the scatter of the next, the first and the last beyond it).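

In this assay the fluoro group adds a new kind of change at this position, and the step of a 1.5-fold higher number from compound 2 to compound 4 (0.18 log units; within the scatter) stays within the scatter, so this single fluoro group on the 2-hydroxyphenyl ring cannot be told apart from hydrogen. The step of a 1.7-fold lower number from compound 3 to compound 4 (0.23 log units; within the scatter) is also within the scatter, so compound 4 separates clearly from neither compound 2 nor compound 3, even though those two differ beyond the scatter. Nothing in the data given here accounts for these numbers.

Going by these compounds, whether a methoxy group in place of the hydroxy, or an amine on the same ring, would give a number clearly apart from these remains open. So does the effect of a fluoro group on a phenyl ring that carries no hydroxy.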